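The compounds below may be only part of what the source reports. "The series", "measured", "known", "first", "only" and "open" are said of these compounds alone.

Measured compounds, solubility in a physicochemical assay for solubility, in phosphate buffer, at pH 6.5; a lower number here means a less soluble compound, a higher number a more soluble compound:
- compound 1 `CNc1nc(NCCCN(C)C)c2sc(-c3ccc(S(C)(=O)=O)cc3)cc2n1`: 25 ug/mL
- compound 2 `CNc1nc(NCCCN(C)C)c2sc(-c3ccc(NS(C)(=O)=O)cc3)cc2n1`: 25 ug/mL
- compound 3 `CNc1nc(NCCCN(C)C)c2sc(-c3ccc(OC)nc3)cc2n1`: 25 ug/mL

Compound 2 stands level with compound 1 and compound 3 at the digits given; its nearest neighbour is compound 1, and even the furthest, compound 3, shows no separation beyond the scatter. The three share one core and differ only in the aryl substituent attached to it, and none of those differences moves this assay.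

The next compound, compound 4 `CNc1nc(NCCCN(C)C)c2sc(-c3ccccc3)cc2n1`, arises from compound 2 by the change (hydrogen in place of methanesulfonamido on an aromatic carbon).

Among the measured compounds shown here, the only measured step that touches this position is the one from compound 1 to compound 2, no change at the digits printed from compound 1 to compound 2 (within the scatter), which swaps one sulfur-bearing group for another and is flat. For the measured compounds named here, no measured step removes a group at this position altogether, so the expectation for compound 4 rests on the flatness across compounds 1 to 3 alone. A small step downward, possibly within the scatter, is expected for compound 4 in this assay, as a 1.7-fold lower number from compound 2 to compound 4 (0.22 log units; within the scatter).

Compound 4 is estimated at 15 ug/mL, with a range from 5 ug/mL to 40 ug/mL.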

Compound 4, solubility: > 100 ug/mL
Compound 4 was reported as a limit; the forecaster's own chance of this, stated with the estimate: 5%; middle value at least 6.6-fold (0.82 log units) from the limit.
By their numbers in this assay, from the lowest: compounds 1, 2 and 3 (each within the scatter of the next). At a limit, above all of these: compound 4.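

In this assay the position is not silent: hydrogen in place of methanesulfonamido gives an at least 4.0-fold higher number from compound 2 to compound 4 (0.60 log units; beyond the scatter) and hydrogen in place of methylsulfonyl gives an at least 4.0-fold higher number from compound 1 to compound 4 (0.60 log units; beyond the scatter) while phenyl in place of 6-methoxypyridin-3-yl gives an at least 4.0-fold higher number from compound 3 to compound 4 (0.60 log units; beyond the scatter) and all three steps run the same way, with no listed compound against them. Among the compounds shown here, the earlier level readings of compounds 1, 2 and 3 therefore show only that these three aryl groups match one another, not that the read-out is indifferent to what sits on this aromatic carbon, para to a large group, since the bare phenyl of compound 4 separates from all of them. The value of compound 4 is a limit, so each of these steps gives only a lower bound on its size: the limit of > 100 ug/mL in this assay, at which 1 of the 4 values shown sits.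

As far as these compounds go, how far compound 4 lies past that limit remains unknown, so the full size of the change cannot be stated. Also open, from the compounds shown here alone, is which substituents on the phenyl ring keep compound 4's level and which return to that of compounds 1, 2 and 3, for instance a methyl, a fluorine, an amine or a carboxylic acid at this position.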